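Benzamide series: trifluoromethyl exchanged for phenoxy

The source may report more compounds than this note shows. Statements on the series, on what has been measured and on what is new or still open speak of the compounds shown alone.

Compound 1 `Cc1ccccc1C(=O)OC(CCN(C)C)c1ccc(Cl)cc1` gives 1700 nM in an assay on NIH3T3 cells with Urotensin-2 receptor (Homo sapiens) as the target (a higher number here means that more compound is needed for the effect, a lower number that less compound is needed), compound 2 `COc1ccc(C(=O)NC(CCN(C)C)c2ccc(Cl)cc2)cc1` gives 1350 nM, and compound 3 `CN(C)CCC(NC(=O)c1ccc(C(F)(F)F)cc1)c1ccc(Cl)cc1` gives 77.6 nM, the lowest of the three numbers, with compound 2 nearest and compound 1 furthest. Among the compounds with values here, the only step with a single change, a 17-fold lower number from compound 2 to compound 3 (1.24 log units; beyond the scatter), is large. Compound 4 `CN(C)CCC(NC(=O)c1ccc(Oc2ccccc2)cc1)c1ccc(Cl)cc1` differs from compound 3 by phenoxy in place of trifluoromethyl on an aromatic carbon. Within the data shown here, no measured step exchanges a trifluoromethyl for a phenoxy, and no measured compound carries a phenoxy, so the step from compound 2 to compound 3 bears on it only by showing that the group at this place can move the number a great deal. The expectation for compound 4 is therefore a moderate rise, a 3.2-fold higher number from compound 3 to compound 4 (0.51 log units; beyond the scatter), with wide uncertainty. The estimate for compound 4 is 250 nM, between 50 nM and 1200 nM.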

Compound 4, half-maximal effective concentration: 66.1 nM
Compound 4: the middle estimate sits 3.8-fold (0.58 log units) above what was measured; low and high end bracket the measured number.
By their numbers in this assay, from the lowest: compounds 4 and 3 (each within the scatter of the next); then compounds 2 and 1 (each within the scatter of the next).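

At this position in this assay the exchange gives a 1.2-fold lower number from compound 3 to compound 4 (0.07 log units; within the scatter), so a phenoxy with its added aromatic ring is tolerated as well as trifluoromethyl, and the site is not limited to a group of that small size. The other step, a 20-fold lower number from compound 2 to compound 4 (1.31 log units; beyond the scatter), shows that the oxygen alone does not set the number: what it carries does. No measurement at hand gives a reason for either step.

Still open, on these data alone, is whether an amine or a carboxylic acid at this position would hold the number, and whether a longer chain on the oxygen would act as phenyl does.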